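Methoxy on the Central Phenyl of a Bis-Isoxazole Scaffold

The source may hold more compounds than are shown below. What is called first, only, known or untested is meant among the compounds shown, and "the series" means these compounds.

Measured compounds:
Compound 1 `Cc1noc2c1N=C(c1ccc(Cl)cc1)CC(c1ccccc1)C2C(c1ccccc1)C1c2onc(C)c2N=C(c2ccc(Cl)cc2)CC1c1ccccc1`: 58.5 ug/mL
Compound 2 `Cc1noc2c1N=C(c1ccccc1)CC(c1ccccc1)C2C(c1ccccc1)C1c2onc(C)c2N=C(c2ccccc2)CC1c1ccccc1`: 66.5 ug/mL
Compound 3 `Cc1noc2c1N=C(c1ccco1)CC(c1ccccc1)C2C(c1ccccc1)C1c2onc(C)c2N=C(c2ccco2)CC1c1ccccc1`: 28.9 ug/mL

Three compounds sharing one core were tested in a functional assay on Ehrlich cells (Homo sapiens) for cytotoxicity, read by MTT assay, with a stated time of 48 h; a lower number here means a stronger inhibitor, a higher number a weaker inhibitor. Compound 1 gives 58.5 ug/mL, compound 2 gives 66.5 ug/mL and compound 3 gives 28.9 ug/mL. Compound 2 carries the highest of the three numbers; the value of compound 1 sits within the scatter of it, while compound 3 lies beyond the scatter with a lower number. Among the measured compounds shown here, no single-point step between measured compounds is available, so the effect of a substituent on the central phenyl is not yet known.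

Compound 4 `COc1ccc(C(C2c3onc(C)c3N=C(c3ccccc3)CC2c2ccccc2)C2c3onc(C)c3N=C(c3ccccc3)CC2c2ccccc2)cc1` is the next compound in line. It differs from compound 2 in one place: methoxy in place of hydrogen on an aromatic carbon. The account now reaches a point where no measurement has yet been made. The available numbers offer no guide for this position, so the step from compound 2 to compound 4 is expected to be small, with no clear direction beyond the scatter, as a 1.1-fold lower number from compound 2 to compound 4 (0.04 log units; within the scatter). Compound 4 is therefore estimated to give 60 ug/mL in this assay, within a range from 30 ug/mL to 120 ug/mL.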

Compound 4, half-maximal inhibitory concentration: 41.9 ug/mL
Compound 4: the middle estimate sits 1.4-fold (0.16 log units) above what was measured, within the range that was stated.
By their numbers in this assay, from the lowest: compounds 3, 4, 1 and 2 (each within the scatter of the next, the first and the last beyond it).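

In this assay, among the compounds shown here, the change from phenyl to 4-methoxyphenyl gives the first reading at this position, a 1.6-fold lower number from compound 2 to compound 4 (0.20 log units; within the scatter), the only step so far in which the compounds differ in one place. Since this step lies within the scatter, the position takes a methoxy group in place of hydrogen without a difference that this assay can separate from the unsubstituted compound. No supporting data bear on this reading. Going by these compounds, it remains open whether another group on this aromatic carbon, such as an amine, a carboxylic acid or a longer chain, would give a step beyond the scatter. Also open, on these data alone, is whether the same methoxy change would read alike on the shared core as it stands in compound 1 or compound 3.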